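This account rests on a few compounds, and the source may have more. Where it says the series, first, only, none or still open, it means among the compounds named here.

Measured in a functional assay for antagonist activity at metabotropic glutamate receptor 5 (Rattus norvegicus); a higher number here means a weaker inhibitor, a lower number a stronger inhibitor:
compound 1 `Cc1ncccc1-c1cc(F)cc(-n2nnc(-c3ccccn3)n2)c1` gives 41 nM
compound 2 `Cc1cncc(-c2cc(F)cc(-n3nnc(-c4ccccn4)n3)c2)c1` gives 499 nM
compound 3 `Nc1ccncc1-c1cc(F)cc(-n2nnc(-c3ccccn3)n2)c1` gives 108 nM

Compound 3 stands second highest of the three numbers. Its nearest neighbour is reached by a 2.6-fold higher number from compound 1 to compound 3 (0.42 log units; beyond the scatter), its furthest by a 4.6-fold lower number from compound 2 to compound 3 (0.66 log units; beyond the scatter).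

Compound 4 `Nc1cccnc1-c1cc(F)cc(-n2nnc(-c3ccccn3)n2)c1` differs from compound 3 by 3-aminopyridin-2-yl in place of 4-aminopyridin-3-yl on an aromatic carbon. The two have the same atoms, joined differently. Within the data shown here, no measured step rearranges the ring nitrogen and the amino group in this way; all three measured steps exchange one pyridyl substitution pattern for another. Those steps show what such exchanges can do: a 12-fold higher number from compound 1 to compound 2 (1.09 log units; beyond the scatter) was large, while a 2.6-fold higher number from compound 1 to compound 3 (0.42 log units; beyond the scatter) and a 4.6-fold lower number from compound 2 to compound 3 (0.66 log units; beyond the scatter) were modest. The direction for compound 4 cannot be read from them, as the comparison set holds no second aminopyridyl arrangement.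

The expected step for compound 4 is therefore a 1.1-fold higher number from compound 3 to compound 4 (0.05 log units; within the scatter), small and uncertain in sign, with a wide range. Compound 4 is estimated at 120 nM in this assay, between 35 nM and 400 nM.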

Compound 4, half-maximal inhibitory concentration: 19 nM
For compound 4 the middle estimate is 6.3-fold (0.80 log units) above the measured one; the whole stated range lies above it.
By their numbers in this assay, from the lowest: compound 4; then compound 1; then compound 3; then compound 2.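

Exchanging 4-aminopyridin-3-yl for 3-aminopyridin-2-yl gives a 5.7-fold lower number from compound 3 to compound 4 (0.75 log units; beyond the scatter) in this assay even though the two groups have the same atoms, so the arrangement of the ring nitrogen and amino group matters here. Against the 2-methylpyridin-3-yl group, the 3-aminopyridin-2-yl group gives a 2.2-fold lower number from compound 1 to compound 4 (0.33 log units; beyond the scatter) and shows that an aminopyridyl group can reach a lower number than the methylpyridyl groups shown, whereas the 4-aminopyridin-3-yl group of compound 3 does not. With a 26-fold lower number from compound 2 to compound 4 (1.42 log units; beyond the scatter) as the widest step in the set, this position responds strongly to the pyridyl substitution pattern, and compound 4 has the lowest number of the four.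

Open, going by these compounds, is whether a methoxy or dimethylamino group in place of the amino group of compound 4 would keep this number. Nothing available here explains the difference between the two aminopyridyl arrangements.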